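The source may report more compounds than this note shows. Statements on the series, on what has been measured and on what is new or still open speak of the compounds shown alone.

Working notes on the series. Compound 1 `CCc1ccc(N(CC(C)C)S(=O)(=O)c2ccc3c(c2)C(O)CC(C(C)C2CCOCC2)O3)cc1`, compound 2 `CCc1ccc(N(CC(C)C)S(=O)(=O)c2ccc3c(c2)C(O)CC(C2CCOCC2)O3)cc1` and compound 3 `CCc1ccc(N(CC(C)C)S(=O)(=O)c2ccc3c(c2)C(O)CC(C2CCN(C)CC2)O3)cc1` share one core and differ only in the group on a saturated ring carbon. In a physicochemical assay for lipophilicity, at pH 7.4 (on this read-out lower numbers stand for lower lipophilicity and higher numbers for higher lipophilicity), compound 1 gives 5.04, compound 2 gives 4.12 and compound 3 gives 2.67, which is the lowest of the three numbers. The measured steps run a number 0.92 log units lower from compound 1 to compound 2 (beyond the scatter), a number 2.37 log units lower from compound 1 to compound 3 (beyond the scatter) and a number 1.45 log units lower from compound 2 to compound 3 (beyond the scatter). Compound 4 `CCc1ccc(N(CC(C)C)S(=O)(=O)c2ccc3c(c2)C(O)CC(C2CCNCC2)O3)cc1` follows from compound 3 by hydrogen in place of methyl on an amine nitrogen in a ring. Going by the values given here, no measured step removes a methyl from an amine nitrogen; each of the three exchanges the whole group on the saturated ring carbon. The closest in kind is a number 0.92 log units lower from compound 1 to compound 2 (beyond the scatter), where the group is kept but shortened, and the change to compound 4 is smaller than that one. For compound 4 a step in this assay of about a number 0.37 log units lower from compound 3 to compound 4 (beyond the scatter) is therefore expected, downward and near the edge of the scatter. Compound 4 is estimated at 2.3, with a range from 1.8 to 2.8.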

Compound 4, distribution coefficient: 1.04
Compound 4: middle estimate off by 1.26 log units, on the high side, outside the stated range (below it).
By their numbers in this assay, from the lowest: compound 4; then compound 3; then compound 2; then compound 1.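

In this assay, the loss of one methyl from the amine nitrogen in the ring gives a large step (a number 1.63 log units lower from compound 3 to compound 4 (beyond the scatter)), on a par with the exchange of the whole ring group (a number 1.45 log units lower from compound 2 to compound 3 (beyond the scatter)). With piperidin-4-yl on the saturated ring carbon the series reaches its lowest number, both against oxan-4-yl (a number 3.08 log units lower from compound 2 to compound 4 (beyond the scatter)) and against 1-(oxan-4-yl)ethyl (a number 4.00 log units lower from compound 1 to compound 4 (beyond the scatter)), so what the ring nitrogen carries matters here as well as the ring itself. Nothing available bears on the cause of the step.

Still open is how an ethyl or an acetyl on the same amine nitrogen would read, since only hydrogen and methyl stand there in the compounds shown. Also open, from the compounds shown here alone, is how 1-(piperidin-4-yl)ethyl would read on the saturated ring carbon.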